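Removing the Iodo Group from Compound 3

The source may hold more compounds than are shown below. What is called first, only, known or untested is meant among the compounds shown, and "the series" means these compounds.

The measured compounds:
Compound 1, `O=C1C(=O)N(CCCCn2cc(COc3cc(=O)oc4ccccc34)nn2)c2ccc([N+](=O)[O-])cc21`: in a functional assay on HCT-116 cells (Homo sapiens) for inhibition, read by sulforhodamine B assay, with a stated time of 48 h, tested at 50 uM (on this read-out lower numbers stand for less inhibition of growth and higher numbers for more inhibition of growth at the one concentration tested), compound 1 gives 53%.
Compound 2, `O=C1C(=O)N(CCCCn2cc(COc3cc(=O)oc4ccccc34)nn2)c2ccc(Br)cc21`: in this assay compound 2 gives 59%.
Compound 3, `O=C1C(=O)N(CCCCn2cc(COc3cc(=O)oc4ccccc34)nn2)c2ccc(I)cc21`: in this assay compound 3 gives 57%.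

All three share one core and differ only in the group on one aromatic carbon. Compound 3 sits between its neighbours: the step of a number 2 percentage points lower from compound 2 to compound 3 (within the scatter) and the step of a number 4 percentage points higher from compound 1 to compound 3 (within the scatter) are both within the scatter, so the three numbers cannot be told apart with confidence.

Compound 4, `O=C1C(=O)N(CCCCn2cc(COc3cc(=O)oc4ccccc34)nn2)c2ccccc21`, keeps the core and differs from compound 3 in one place: hydrogen in place of iodo on an aromatic carbon.

Within the data shown here, three measured steps bear on this change, each a swap of the group at that same aromatic carbon: a number 6 percentage points higher from compound 1 to compound 2 (within the scatter), a number 4 percentage points higher from compound 1 to compound 3 (within the scatter) and a number 2 percentage points lower from compound 2 to compound 3 (within the scatter). None reached beyond the scatter. The group of compound 3 is therefore expected to matter little, and the step of a number 3 percentage points lower from compound 3 to compound 4 (within the scatter) is estimated to stay within the scatter. For compound 4 the estimate in this assay is 54%, with a range from 40% to 68%.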

Compound 4, percent growth inhibition at one concentration: 72%
Compound 4: the middle estimate sits 18 percentage points below what was measured; the measured number lies above the stated range.
By their numbers in this assay, from the lowest: compounds 1, 3 and 2 (each within the scatter of the next); then compound 4.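

In this assay, swapping one group for another at this aromatic carbon changed little, but removing the group altogether did change the result. Replacing each group with hydrogen moved the number beyond the scatter (a number 15 percentage points higher from compound 3 to compound 4 (beyond the scatter); a number 13 percentage points higher from compound 2 to compound 4 (beyond the scatter); a number 19 percentage points higher from compound 1 to compound 4 (beyond the scatter)). Iodo, bromo and nitro therefore sit together, while compound 4, with only hydrogen there, shows more inhibition of growth than any of them, and nothing measured here explains this gap.

On these data alone, it remains open whether hydrogen is unusual or whether other groups at this carbon, such as fluoro, methyl, an amine or a carboxylic acid, would fall with compound 4 or with the other three. Also open, as far as these compounds go, is whether the step to hydrogen would keep its size with a longer chain on the shared core.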